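Lengthening the Acetoxy Chain of Compound 3

The source may hold more compounds than are shown below. What is called first, only, known or untested is meant among the compounds shown, and "the series" means these compounds.

In a functional assay on PBM cells (Homo sapiens) for cytotoxicity (on this read-out lower numbers stand for stronger inhibition and higher numbers for weaker inhibition), compound 1 `O=C1NC(O)C(F)=CN1[C@H]1C=C[C@@H](CO)O1` gives 32200 nM and compound 2 `O=c1[nH]c(=O)n([C@@H]2C=C[C@@H](CO)O2)cc1F` gives 47400 nM, two values within the usual scatter of each other. Compound 3 `CC(=O)OC[C@@H]1C=C[C@H](n2cc(F)c(N)nc2=O)O1` stands only at a limit of this assay, > 100000 nM. Compound 4 `CCCCC(=O)OC[C@@H]1C=C[C@H](n2cc(F)c(N)nc2=O)O1` differs from compound 3 by propyl in place of hydrogen on a saturated chain carbon bound to a carbonyl carbon, which turns acetoxy into (butylcarbonyl)oxy. For the measured compounds named here, no measured pair shows a change of this kind, so the expectation is loose. Compound 2, at 47400 nM, shows that readings with a definite number do occur among these compounds. The expected change is an at least 1.6-fold lower number from compound 3 to compound 4 (0.22 log units; that floor lies within the scatter), a modest step toward stronger inhibition, though another limit reading remains quite possible. For compound 4 the estimated value is 60000 nM, with an expected range of 20000 nM to 100000 nM.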

Compound 4, half-maximal inhibitory concentration: > 100000 nM
Compound 4 gave a limit, no number; the forecaster's own chance of this, stated with the estimate: 50%; at least 1.6-fold (0.22 log units) between middle value and limit.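

Compound 3 and compound 4 both stand at a limit of this assay, so no step can be read between them: the limit of > 100000 nM in this assay, at which 2 of the 4 values shown sit.

The compounds shown leave open whether going from acetoxy to (butylcarbonyl)oxy changes this read-out at all.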